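The source may report more compounds than this note shows. Statements on the series, on what has been measured and on what is new or still open speak of the compounds shown alone.

In an ADME assay on HaCaT cells (Homo sapiens) for inhibition, read by sulforhodamine B assay, with a stated time of 48 h (a lower number here means a stronger inhibitor of growth, a higher number a weaker inhibitor of growth), compound 1 `S=C(N/N=C/c1cccs1)Nc1ccc(Cl)cc1` gives 14700 nM. Compound 2 `S=C(N/N=C/c1cccs1)Nc1ccccc1` stands only at a limit, > 100000 nM. Compound 3 `COc1ccc(NC(=S)N/N=C/c2cccs2)cc1` is also known only as a limit, > 100000 nM. Compound 4 `CCc1ccc(NC(=S)N/N=C/c2cccs2)cc1` has ethyl in place of methoxy on an aromatic carbon, para to a large group: ethyl in place of methoxy on an aromatic carbon. Going by the values given here, two measured steps bear on this change, though neither involves ethyl: an at least 6.8-fold higher number from compound 1 to compound 2 (0.83 log units; beyond the scatter) and an at least 6.8-fold higher number from compound 1 to compound 3 (0.83 log units; beyond the scatter). Both lie beyond the scatter, and both show that replacing chloro loses growth inhibition. The remaining step is a step that the two limits leave unreadable from compound 2 to compound 3. A modest move to a lower number is expected in this assay, although compound 4 may also stay at the limit. The expected change is an at least 2.0-fold lower number from compound 3 to compound 4 (0.30 log units; that floor lies within the scatter). Compound 4 is estimated at 50000 nM, within 15000 nM to 100000 nM.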

Compound 4, concentration for 50% growth inhibition: 17600 nM
Compound 4: the middle estimate sits 2.8-fold (0.45 log units) above what was measured, and the stated range covers the measured number.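

In this assay, ethyl para to a large group brings back measurable growth inhibition: an at least 5.6-fold lower number from compound 3 to compound 4 (0.75 log units; beyond the scatter), and an at least 5.6-fold lower number from compound 2 to compound 4 (0.75 log units; beyond the scatter). Chloro is no longer the only group here with a number, since a 1.2-fold higher number from compound 1 to compound 4 (0.08 log units; within the scatter) leaves ethyl and chloro level. The two larger steps are floors, and their true size stays unknown: the limit of > 100000 nM in this assay, at which 2 of the 4 values shown sit.

Going by these compounds, whether a longer chain such as butyl holds this level stays open. So does whether an amine or a carboxylic acid at this position gives a readable value.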